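This account rests on a few compounds, and the source may have more. Where it says the series, first, only, none or still open, it means among the compounds named here.

In a functional assay on A549 cells (Homo sapiens) for antiproliferative activity, read by sulforhodamine B assay, with a stated time of 48 h (a higher number here means a weaker inhibitor, a lower number a stronger inhibitor), three compounds have been measured:

Compound 1 `COc1ccc(OC)c(/C=C/C(=O)/C=C(O)/C=C/c2cc(OC)ccc2OC)c1`: 16300 nM
Compound 2 `COc1ccc(C=C(C(=O)/C=C/c2cccc(OC)c2OC)C(=O)/C=C/c2cccc(OC)c2OC)cc1OC`: 170 nM
Compound 3 `COc1ccc(OC)c(/C=C/C(=O)C(=Cc2ccc(OC)c(OC)c2)C(=O)/C=C/c2cc(OC)ccc2OC)c1`: 400 nM

Compound 3 holds the second highest of these three numbers. Its distance to compound 2 lies beyond the scatter, as does its much larger distance to compound 1. Compound 4 `COc1ccc(OC)c(/C=C/C(=O)C(=Cc2ccc(OC)c(O)c2)C(=O)/C=C/c2cc(OC)ccc2OC)c1` departs from compound 3 in a single place: hydrogen in place of methyl on an oxygen on an aromatic ring. For the measured compounds named here, no measured pair shows this change, so only a small step in this assay is expected, perhaps toward a lower number and possibly none beyond the scatter. The expected move is a 1.3-fold lower number from compound 3 to compound 4 (0.12 log units; within the scatter). For compound 4 the estimated value is 300 nM, with an expected range from 110 nM to 800 nM.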

Compound 4, half-maximal inhibitory concentration: 390 nM
The estimate for compound 4 lay 1.3-fold (0.11 log units) below the measured number; the range from low to high includes it.
By their numbers in this assay, from the lowest: compound 2; then compounds 4 and 3 (each within the scatter of the next); then compound 1.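

In this assay, going from the 3,4-dimethoxyphenyl group to the 3-hydroxy-4-methoxyphenyl group, methoxy to hydroxy, gives no change beyond the scatter (a 1.0-fold lower number from compound 3 to compound 4 (0.01 log units; within the scatter)). For the compounds shown here, this is the first reading of this change at this place, and it shows that the methyl on this oxygen can give way to hydrogen with the number held. Nothing available explains this result.

Going by these compounds, whether an amine or a longer chain such as ethoxy at this place would also hold the number remains open. So does the effect of the same change on the other aromatic rings.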